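The compounds below may be only part of what the source reports. "The series", "measured", "known", "first", "only" and "open" are said of these compounds alone.

Compound 1 `CCCOCC(=O)Nc1cc2nc(C3CCCCC3)[nH]c2cc1N(C)C` gives < 50 ug/mL in an ADME assay on Vero cells (Chlorocebus sabaeus) for cytotoxicity, read by resazurin assay, with a stated time of 3 days; a higher number here means a weaker inhibitor, a lower number a stronger inhibitor.
Compound 2 `CCCCOC(=O)Nc1cc2nc(C3CCCCC3)[nH]c2cc1N(CC)CC` gives > 100 ug/mL in this assay.
Compound 3 `CCN(CC)c1cc2[nH]c(C3CCCCC3)nc2cc1NC(=O)c1cnccn1` gives > 100 ug/mL in this assay.

None of these three results is an actual number: each is a limit of the assay. Compound 1 stands at the limit of < 50 ug/mL in this assay, at which 1 of the 3 values shown sits, so its true value is known only to lie on the stronger side of that mark. Compound 2 stands at the limit of > 100 ug/mL in this assay, at which 2 of the 3 values shown sit. Compound 3 stands at the same (the limit of > 100 ug/mL in this assay, at which 2 of the 3 values shown sit). Going by the values given here, the one step between measured compounds that differ in a single place, a step that the two limits leave unreadable from compound 2 to compound 3, therefore has no readable size, both of its ends being limits, and it gives no guide to how changing the group on the carbonyl carbon moves cytotoxicity.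

Compound 4 `CN(C)c1cc2[nH]c(C3CCCCC3)nc2cc1NC(=O)c1ccc(C(C)(C)C)cc1` is the next compound, and it differs from compound 1 by 4-(tert-butyl)phenyl in place of propoxymethyl on a carbonyl carbon. Among the compounds with values here, no measured step bears directly on this exchange. Within the data shown here, the only anchor is that compound 1 itself already lies on the stronger side of its limit. Compound 4 is expected to give 25 ug/mL, with a likely range from 8 ug/mL to 80 ug/mL. The implied step, a step that the limit leaves unreadable from compound 1 to compound 4, is an estimate whose size cannot be checked against the scatter while compound 1 remains only a limit.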

Compound 4, half-maximal inhibitory concentration: > 100 ug/mL
Compound 4 gave a limit, no number; the forecaster's own chance of this, stated with the estimate: 45%; middle value at least 4.0-fold (0.60 log units) from the limit.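

Compound 4 rests on a limit of the assay, not on a number: the limit of > 100 ug/mL in this assay, at which 3 of the 4 values shown sit. Compound 1 also rests on a limit of the assay, one that points the other way: the limit of < 50 ug/mL in this assay, at which 1 of the 4 values shown sits. Unlike the earlier pair, whose limits left the step without a readable size, this exchange of propoxymethyl for 4-(tert-butyl)phenyl on a carbonyl carbon gives a step with a readable floor in this assay, namely an at least 2.0-fold higher number from compound 1 to compound 4 (0.30 log units; that floor lies within the scatter), although that floor alone does not separate the two compounds beyond the usual scatter.

From the compounds shown here alone, the true distance between compound 1 and compound 4 stays open, since neither compound has an actual number here, and a single exchange says nothing about which part of the new group matters. The compounds shown also leave open how a plain phenyl without the tert-butyl group, a phenyl bearing a carboxylic acid or an amine, or a longer chain ending in an ether oxygen would behave at this same place on the carbonyl carbon.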